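Working notes: replacing the formyl group of compound 3

The source may hold more compounds than are shown below. What is called first, only, known or untested is meant among the compounds shown, and "the series" means these compounds.

Measured in an ADME assay on BJ cells (Homo sapiens) for cytotoxicity, with a stated time of 72 h; a lower number here means that less compound is needed, a higher number that more compound is needed for the effect:
- Compound 1 `C=C[C@@](C)(/C=C/c1ccc(O)cc1)CC/C=C(C)/C=N/N`: > 36600 nM (a limit of the assay)
- Compound 2 `C=C[C@@](C)(/C=C/c1ccc(O)c(/C=C/c2ccc(F)cc2)c1)CCC=C(C)C`: > 36600 nM (a limit of the assay)
- Compound 3 `COc1ccc(/C=C/[C@@](C)(/C=C/c2ccc(O)c(C=O)c2)CCC=C(C)C)cc1`: 9800 nM

Among the measured compounds shown here, compound 3 is the only compound here with a true number, 9800 nM. The other two stand at the limit of > 36600 nM in this assay, at which 2 of the 3 values shown sit.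

Compound 4 `COc1ccc(/C=C/[C@@](C)(/C=C/c2ccc(O)c(/C=C/C(=O)OC(C)(C)C)c2)CCC=C(C)C)cc1` carries 2-(tert-butoxycarbonyl)ethenyl in place of formyl on an aromatic carbon, ortho to a hydroxy group (2-(tert-butoxycarbonyl)ethenyl in place of formyl on an aromatic carbon). For the measured compounds named here, no measured step covers this change, so the expectation is loose, and no step beyond the scatter is expected in this assay. The expected change is a 1.4-fold higher number from compound 3 to compound 4 (0.15 log units; within the scatter). For compound 4 the estimated value is 14000 nM, with an expected range of 4500 nM to 36600 nM.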

Compound 4, half-maximal effective concentration: > 36600 nM
Compound 4: no number, only a limit; the forecaster's own chance of this, stated with the estimate: 35%; middle value at least 2.6-fold (0.41 log units) away from the limit.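

In this assay, the position ortho to a hydroxy group now has a step of its own: 2-(tert-butoxycarbonyl)ethenyl in place of formyl gives an at least 3.7-fold higher number from compound 3 to compound 4 (0.57 log units; beyond the scatter). Compound 4 gives > 36600 nM, which is a limit and not a number, so this step has a lower bound only. Compound 3, with formyl, remains the only compound with a true number, and compound 4 joins the others at the limit: the limit of > 36600 nM in this assay, at which 3 of the 4 values shown sit.

Going by these compounds, whether the step follows the larger size of the entering group or the ester itself stays open. A carboxylic acid or a hydroxymethyl group on this carbon would bear on that question.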